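This account rests on a few compounds, and the source may have more. Where it says the series, first, only, none or still open, it means among the compounds named here.

Measured so far in a functional assay on A549 cells (Homo sapiens) for antiproliferative activity, read by MTT assay, with a stated time of 72 h; on this read-out higher numbers stand for weaker inhibition and lower numbers for stronger inhibition
- compound 1 `O=C(N/N=C/c1ccc(Br)cc1)Nc1ccc(Oc2ccnc3[nH]ccc23)cc1` gives 640 nM
- compound 2 `O=C(N/N=C/c1ccc(O)cc1Br)Nc1ccc(Oc2ccnc3[nH]ccc23)cc1` gives 5080 nM

Compound 2, at 5080 nM, holds the higher of the two numbers, so it shows the weaker inhibition of the pair. The next structure, compound 3 `CN(C)CCn1cccc1/C=N/NC(=O)Nc1ccc(Oc2ccnc3[nH]ccc23)cc1`, keeps the shared core and changes only the group on the carbon with a double bond to nitrogen: 1-(2-(dimethylamino)ethyl)-1H-pyrrol-2-yl in place of 2-bromo-4-hydroxyphenyl on a carbon with a double bond to nitrogen. Within the data shown here, one measured step bears on this, because it changes the same place: a 7.9-fold higher number from compound 1 to compound 2 (0.90 log units; beyond the scatter). That step is modest but beyond the scatter, so the number in this assay does respond to a change here. Among the measured compounds shown here, no compound with a pyrrole ring has been measured yet, which makes this only indirect evidence. Compound 2 sits at the high end, and compound 1 at 640 nM is the only other reference, so a modest downward step is expected, perhaps smaller than the one already seen. The expected change is a 3.4-fold lower number from compound 2 to compound 3 (0.53 log units; beyond the scatter). For compound 3 the estimated value is 1500 nM, with an expected range from 300 nM to 7000 nM.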

Compound 3, half-maximal inhibitory concentration: "not active" (no number reported)
No number was reported for compound 3; the estimate stays without a comparison.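

In this assay, among these compounds, compound 3 is reported as "not active" without a number, so no step from compound 2 to compound 3 can be read. No other measurement shown here bears on this result. The compounds shown leave open how far compound 3 actually lies from compound 2 on this read-out.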